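Removing the methylpiperidinyl group from the pyrazole nitrogen

The source may report more compounds than this note shows. Statements on the series, on what has been measured and on what is new or still open speak of the compounds shown alone.

For the measured compounds named here, compound 2 `Cc1ccc(CNC(=O)c2cccc(C(C)Oc3ccnc(Nc4cnn(C5CCN(C)CC5)c4)c3)c2)cc1` gives 8900 nM in a functional assay on NCI-H3122 cells (Homo sapiens) for antiproliferative activity, read by MTT assay, with a stated time of 48 h (on this read-out higher numbers stand for weaker inhibition and lower numbers for stronger inhibition), the higher of the two numbers measured so far, with compound 3 `CC(Oc1ccnc(Nc2cnn(C3CCN(C)CC3)c2)c1)c1cccc(C(=O)NCc2ccc(Cl)c(C(F)(F)F)c2)c1` nearby at 8000 nM. The step of a 1.1-fold lower number from compound 2 to compound 3 (0.05 log units; within the scatter) shows that changing the aryl group on the saturated chain carbon bound to the amide-type nitrogen leaves the read-out within the scatter. Compound 1 `COc1cccc(CNC(=O)c2cccc(C(C)Oc3ccnc(Nc4cnn(C)c4)c3)c2)c1` sits at the limit of > 100000 nM in this assay, at which 1 of the 3 values shown sits, so its value > 100000 nM is a limit and not a number.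

Compound 4 `Cc1ccc(CNC(=O)c2cccc(C(C)Oc3ccnc(Nc4cnn(C)c4)c3)c2)cc1` differs from compound 2 by methyl in place of 1-methylpiperidin-4-yl on an aromatic nitrogen. Going by the values given here, no measured step covers this change directly. Compound 1, however, carries the same methyl on the aromatic nitrogen and differs from compound 4 only in the aryl group on the saturated chain carbon, the kind of variation that in the step of a 1.1-fold lower number from compound 2 to compound 3 (0.05 log units; within the scatter) stayed within the scatter. A large rise in the number is therefore expected, a 7.9-fold higher number from compound 2 to compound 4 (0.90 log units; beyond the scatter). Compound 4 is estimated at 70000 nM, between 20000 nM and 250000 nM, with a real chance that this assay returns only a limit.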

Compound 4, half-maximal inhibitory concentration: 7700 nM
For compound 4 the middle estimate is 9.1-fold (0.96 log units) above the measured one; measured number below the stated range.
By their numbers in this assay, from the lowest: compounds 4, 3 and 2 (each within the scatter of the next). At a limit, above all of these: compound 1.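

On the aromatic nitrogen of the five-membered ring, methyl stands in for 1-methylpiperidin-4-yl with no change beyond the scatter in this assay (a 1.2-fold lower number from compound 2 to compound 4 (0.06 log units; within the scatter)). With methyl on that nitrogen in both compounds, the step beyond the scatter comes instead with 4-methylphenyl in place of 3-methoxyphenyl on the saturated chain carbon (an at least 12-fold lower number from compound 1 to compound 4 (1.11 log units; beyond the scatter)). The value of compound 1 is a limit and not a number, so that step has no fixed size: (the limit of > 100000 nM in this assay, at which 1 of the 4 values shown sits).

Still open, from the compounds shown here alone, is whether 3-methoxyphenyl gives the same high reading with 1-methylpiperidin-4-yl on the aromatic nitrogen, and whether 4-chloro-3-(trifluoromethyl)phenyl keeps its reading with methyl there. Also open, going by these compounds, is how a 2-(dimethylamino)ethyl chain or a carboxylic acid on that nitrogen would read.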